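Cyclopentyl for cyclopropylmethyl on a chlorinated pyridazinone core

The compounds below may be only part of what the source reports. "The series", "measured", "known", "first", "only" and "open" are said of these compounds alone.

Two pairs of compounds share one structural change. Compound 1 `COc1ccccc1OCCNc1ccc(=O)n(Cc2ccc(OC)c(OC3CCCC3)c2)n1` and compound 2 `COc1ccccc1OCCNc1ccc(=O)n(Cc2ccc(OC)c(OCC3CC3)c2)n1` have the same core; in a functional assay on K562 cells (Homo sapiens) for antiproliferative activity, read by MTT assay, with a stated time of 48 h (a higher number here means a weaker inhibitor of growth, a lower number a stronger inhibitor of growth), compound 2 gives 16600 nM, and compound 1 gives 28000 nM. The change between them is cyclopentyl in place of cyclopropylmethyl on an oxygen on an aromatic ring, and it made a step of a 1.7-fold higher number from compound 2 to compound 1 (0.23 log units; within the scatter). Compound 3 `COc1ccccc1OCCNc1cnn(Cc2ccc(OC(F)F)c(OCC3CC3)c2)c(=O)c1Cl` has a different core; the difference between the two cores is not broken down here. In this assay compound 3 gives 67600 nM, the highest number of the three measured, beyond the scatter from both compound 1 and compound 2. Compound 4 `COc1ccccc1OCCNc1cnn(Cc2ccc(OC(F)F)c(OC3CCCC3)c2)c(=O)c1Cl` has not yet been measured. It differs from compound 3 by cyclopentyl in place of cyclopropylmethyl on an oxygen on an aromatic ring, the same change as between compound 2 and compound 1, at the same place. Because the step of a 1.7-fold higher number from compound 2 to compound 1 (0.23 log units; within the scatter) was small, compound 4 is expected to sit close to compound 3, with a step of a 1.4-fold higher number from compound 3 to compound 4 (0.15 log units; within the scatter). Compound 4 is therefore estimated at 95000 nM in this assay, with a likely range from 40000 nM to 220000 nM.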

Compound 4, concentration for 50% growth inhibition: > 100000 nM
Compound 4 gave a limit, no number (the forecaster's own chance of this, stated with the estimate: 25%); middle value at least 1.0-fold (0.02 log units) from the limit.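

In this assay, compound 4 gives > 100000 nM, which is a limit of the assay and not a number. Swapping cyclopropylmethyl for cyclopentyl on the core of compound 3 therefore has only a lower bound as its size, an at least 1.4-fold higher number from compound 3 to compound 4 (0.17 log units; that floor lies within the scatter), and the true step could be small or much larger. The two cores show no sign that this change behaves differently from one to the other, but they do not show that it carries over unchanged either: the same change on two cores in this assay, a 1.7-fold higher number (0.23 log units; within the scatter) from compound 2 to compound 1 and an at least 1.4-fold higher number (0.17 log units; that floor lies within the scatter) from compound 3 to compound 4; the limit leaves it open whether they differ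

Going by these compounds, the size of the step on the core of compound 3 stays open, as it would take a real number for compound 4 to settle it. The compounds shown also leave open how other groups on this oxygen would behave on either core, such as a longer open chain like n-hexyl or a chain ending in an amine.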